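This account rests on a few compounds, and the source may have more. Where it says the series, first, only, none or still open, it means among the compounds named here.

Measured compounds:
Compound 1 `Nc1nc(-c2ccc(C(F)F)o2)nc2sc(Cc3ccccc3)cc12` gives 3000 nM in a functional assay on CHO-K1 cells for antagonist activity at adenosine receptor A1 (Homo sapiens), read by a beta-galactosidase reporter and cAMP accumulation, with stated times of 15 min and 6 h; a higher number here means a weaker inhibitor, a lower number a stronger inhibitor.
Compound 2 `Cc1csc(-c2nc(N)c3cc(Cc4ccccc4)sc3n2)n1` gives 1490 nM in this assay.
Compound 3 `COc1cccc(-c2nc(N)c3cc(Cc4ccccc4)sc3n2)c1` gives 266 nM in this assay.

Among these three, compound 3 holds the lowest number, and both of its steps are beyond the scatter: a 5.6-fold lower number from compound 2 to compound 3 (0.75 log units; beyond the scatter) and an 11-fold lower number from compound 1 to compound 3 (1.05 log units; beyond the scatter). The two five-membered heteroaryl groups therefore give weaker inhibitors than the 3-methoxyphenyl, while the step of a 2.0-fold lower number from compound 1 to compound 2 (0.30 log units; within the scatter) lies within the scatter.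

Compound 4 `Nc1nc(-c2ccccn2)nc2sc(Cc3ccccc3)cc12` differs from compound 3 in one place: pyridin-2-yl in place of 3-methoxyphenyl on an aromatic carbon. Among the compounds with values here, no measured pair shows a six-membered ring with one hetero atom at this position, so the closest guidance is the pair of steps in which 3-methoxyphenyl replaced a heteroaryl group. Both of those steps lowered the number, one modestly and one by a large amount. Moving from 3-methoxyphenyl back to a heteroaryl group, here a pyridin-2-yl that keeps a six-membered ring, is expected to raise the number, though by less than the step seen for the five-membered rings. Compound 4 is thus estimated to give 800 nM in this assay, within a range of 250 nM to 2500 nM. This expected step, a 3.0-fold higher number from compound 3 to compound 4 (0.48 log units; beyond the scatter), would leave compound 4 between compound 3 and compound 2.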

Compound 4, inhibition constant: 3710 nM
Compound 4: the middle estimate sits 4.6-fold (0.67 log units) below what was measured; measured number outside the range, above it.
By their numbers in this assay, from the lowest: compound 3; then compounds 2, 1 and 4 (each within the scatter of the next, the first and the last beyond it).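

Keeping a six-membered aromatic ring on the aromatic carbon between two ring nitrogen atoms does not by itself hold the level of compound 3 in this assay. The change to pyridin-2-yl gives a 14-fold higher number from compound 3 to compound 4 (1.14 log units; beyond the scatter) and so costs as much as a large step. Ring size therefore does not sort these groups: a 2.5-fold higher number from compound 2 to compound 4 (0.40 log units; beyond the scatter) puts the pyridin-2-yl on the weaker side of the 4-methyl-1,3-thiazol-2-yl even though it has the larger ring, while a 1.2-fold higher number from compound 1 to compound 4 (0.09 log units; within the scatter) leaves it level with the 5-(difluoromethyl)furan-2-yl, and all three heteroaryl groups give higher numbers than the 3-methoxyphenyl. Nothing in the data shown accounts for the size of this step.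

As far as these compounds go, what stays open is whether the higher number of compound 4 goes with the ring nitrogen or with the missing methoxy group, as the two change together in this one step. An unsubstituted phenyl and a pyridine ring carrying a methoxy group on this same carbon would separate those two changes.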